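The compounds below may be only part of what the source reports. "The series", "measured", "known", "first", "only" and "open" are said of these compounds alone.

Measured in an ADME assay on MT4 cells (Homo sapiens) for cytotoxicity, read by MTT assay, with a stated time of 5 days; on this read-out lower numbers stand for higher toxicity in this test and higher numbers for lower toxicity in this test:

- Compound 1 `COc1cc2nc(SCC(=O)Nc3cc([N+](=O)[O-])ccc3F)nc(Nc3c(Cl)cc(/C=C/C#N)cc3Cl)c2cc1OC`: > 199000 nM (a limit)
- Compound 2 `COc1cc2nc([S+]([O-])CC(=O)Nc3ccc(C(F)(F)F)cc3)nc(Nc3c(C)cc(/C=C/C#N)cc3C)c2cc1OC`: 52200 nM
- Compound 3 `COc1cc2nc([S+]([O-])CC(=O)Nc3cccc(Cl)c3)nc(Nc3c(Cl)cc(/C=C/C#N)cc3Cl)c2cc1OC`: 68900 nM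

The value of compound 1 is a limit and not a number. Compound 3 at 68900 nM and compound 2 at 52200 nM lie within the scatter of each other. Compound 4 `COc1cc2nc([S+]([O-])CC(=O)Nc3cccc(F)c3)nc(Nc3c(Cl)cc(/C=C/C#N)cc3Cl)c2cc1OC` turns the 3-chlorophenyl of compound 3 into 3-fluorophenyl, with fluoro in place of chloro on an aromatic carbon. Within the data shown here, no measured pair differs in one place, so the expectation rests on compound 3 at 68900 nM alone. In this assay the expected 1.1-fold higher number from compound 3 to compound 4 (0.04 log units; within the scatter) stays within the scatter. Compound 4 is estimated at 75000 nM, with an expected range of 32000 nM to 190000 nM.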

Compound 4, half-maximal cytotoxic concentration: 9550 nM
Compound 4: the middle estimate sits 7.9-fold (0.90 log units) above what was measured; the measured number lies below the stated range.
By their numbers in this assay, from the lowest: compound 4; then compounds 2 and 3 (each within the scatter of the next). At a limit, above all of these: compound 1.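

In this assay, the halogen on an aromatic carbon, meta to a large group, matters: a 7.2-fold lower number from compound 3 to compound 4 (0.86 log units; beyond the scatter) follows from fluoro in place of chloro. Among these compounds, this is the first step read between compounds differing in one place, and it shows that this single-atom change alone moves the number toward higher toxicity in this test. Nothing at hand gives a cause for this step.

Open, on these data alone, is whether an amine or a carboxylic acid at this position would shift the number further. Also open, as far as these compounds go, is whether the same change elsewhere on this ring would give a step of similar size.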